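This account rests on a few compounds, and the source may have more. Where it says the series, first, only, none or still open, it means among the compounds named here.

Within the data shown here, compound 1 `C/C(=N\N=C1/SCC(=O)N1Cc1cccc(F)c1)c1cccs1` is the one member of this set with a numbered result: in a physicochemical assay, with a stated time of 10 min (a lower number here means a stronger inhibitor, a higher number a weaker inhibitor), compound 1 gives 4640000 nM. Compound 2 `CC(C)=N/N=C1\SCC(=O)N1Cc1cccc([N+](=O)[O-])c1` is known only as a limit of the assay; in this assay compound 2 gives > 5000000 nM. Of the two results shown, that of compound 1 is therefore the only number, since the limit of > 5000000 nM in this assay, at which 1 of the 2 values shown sits, is a limit and not a number, and no step between measured compounds can be drawn. The unmeasured compound 3 `C/C(=N\N=C1/SCC(=O)N1Cc1ccccc1F)c1cccs1` keeps the shared core and differs from compound 1 in one place (2-fluorophenyl in place of 3-fluorophenyl on a saturated chain carbon bound to an amide-type nitrogen in a ring). Among the measured compounds shown here, nothing among the measured compounds points to a step of any size in either direction, so the expected step is a 1.0-fold lower number from compound 1 to compound 3 (0.01 log units; within the scatter), within the usual scatter. In this assay compound 3 is estimated at 4500000 nM, with a range from 1500000 nM to 12000000 nM, and a real chance that only a limit is reported.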

Compound 3, half-maximal inhibitory concentration: 3840000 nM
The estimate for compound 3 lay 1.2-fold (0.07 log units) above the measured number; low and high end bracket the measured number.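

In this assay, 2-fluorophenyl in place of 3-fluorophenyl on a saturated chain carbon bound to an amide-type nitrogen in a ring gives a 1.2-fold lower number from compound 1 to compound 3 (0.08 log units; within the scatter). Among these compounds, this is the first step that can be read in the set, and it shows that the two placements of the fluorine on this phenyl ring cannot be told apart in this assay. Both numbers also stay close to the one result that is only a limit, which belongs to compound 2 and gives no step: the limit of > 5000000 nM in this assay, at which 1 of the 3 values shown sits.

The compounds shown leave open whether any group at this place can move the number beyond the scatter, such as a phenyl ring carrying a carboxylic acid or an amine, or a longer chain in place of the single saturated carbon. They also leave open how far changes elsewhere on the shared core would reach.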